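Benzyl for methyl on the sulfonyl of compound 2

The source may report more compounds than this note shows. Statements on the series, on what has been measured and on what is new or still open speak of the compounds shown alone.

Measured so far:
- compound 1 `CC(C)(C)OC(=O)N1CCC(CN(Cc2ccc(Cl)cc2)Cc2ccc([N+](=O)[O-])s2)C1`: 1800 nM
- compound 2 `CS(=O)(=O)N1CCC(CN(Cc2ccc(Cl)cc2)Cc2ccc([N+](=O)[O-])s2)C1`: 570 nM

Going by the values given here, in a functional assay on HEK293 cells for agonist activity at nuclear receptor subfamily 1 group D member 1 (Homo sapiens), read by a luciferase reporter, with a stated time of 24 h (on this read-out higher numbers stand for an effect only at larger amounts of compound and lower numbers for an effect already at smaller amounts), compound 2 holds the lower of the two numbers, and the only measured step, a 3.2-fold lower number from compound 1 to compound 2 (0.50 log units; beyond the scatter), separates it from compound 1. Compound 3 `O=[N+]([O-])c1ccc(CN(Cc2ccc(Cl)cc2)CC2CCN(S(=O)(=O)Cc3ccccc3)C2)s1` carries phenyl in place of hydrogen on a saturated chain carbon bound to a sulfonyl sulfur, so methylsulfonyl becomes benzylsulfonyl. Among the compounds with values here, no measured pair tests this change; the one known step concerns a different exchange on the same ring nitrogen, so it gives only a weak lead. For compound 3 the expected step is a 1.1-fold higher number from compound 2 to compound 3 (0.02 log units; within the scatter), not clearly beyond the scatter. Compound 3 is therefore estimated at 600 nM, within 200 nM to 1800 nM.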

Compound 3, half-maximal effective concentration: 630 nM
For compound 3 the middle estimate is 1.1-fold (0.02 log units) below the measured one; low and high end bracket the measured number.
By their numbers in this assay, from the lowest: compounds 2 and 3 (each within the scatter of the next); then compound 1.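

In this assay, the step of a 1.1-fold higher number from compound 2 to compound 3 (0.04 log units; within the scatter) stays within the scatter, so a phenyl on the saturated chain carbon bound to the sulfonyl sulfur is tolerated at this position. The step of a 2.9-fold lower number from compound 1 to compound 3 (0.46 log units; beyond the scatter) shows that benzylsulfonyl, like methylsulfonyl, gives a lower number than tert-butoxycarbonyl on the ring nitrogen. No measured evidence here explains why the phenyl leaves the number unchanged. Still open, on these data alone, is whether a longer chain between sulfonyl and phenyl, or an amine or carboxylic acid on that phenyl, would be tolerated as well.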